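Solubility of a urea series: predicting a hydroxyphenyl analogue

This account rests on a few compounds, and the source may have more. Where it says the series, first, only, none or still open, it means among the compounds named here.

Measured so far:
Compound 1, `Cc1cc(NC(=O)Nc2ncccc2C)c2ccccc2n1`, gives 1300 nM in a physicochemical assay for solubility, at pH 7.4; on this read-out lower numbers stand for lower solubility and higher numbers for higher solubility.
Compound 2, `Cc1cc(NC(=O)Nc2ccc(N)cc2)c2ccccc2n1`, gives 18500 nM in this assay.
Compound 3, `Cc1cc(NC(=O)Nc2ccccc2F)c2ccccc2n1`, gives 3800 nM in this assay.

Compound 3 stands second highest of the three in this assay: its nearest neighbour is compound 1, a step of a 2.9-fold higher number from compound 1 to compound 3 (0.47 log units; beyond the scatter), and its furthest is compound 2, a step of a 4.9-fold lower number from compound 2 to compound 3 (0.69 log units; beyond the scatter). The new compound 4, `Cc1cc(NC(=O)Nc2ccc(O)cc2)c2ccccc2n1`, differs from compound 3 in one place: 4-hydroxyphenyl in place of 2-fluorophenyl on an amide-type nitrogen.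

Going by the values given here, the step that bears most directly on this change is the one from compound 2 to compound 3, which moved a polar group off the ring and gave a 4.9-fold lower number from compound 2 to compound 3 (0.69 log units; beyond the scatter). Compound 4 largely reverses that move, so a higher number in this assay is expected, though a hydroxyl need not behave exactly as an amino group did in compound 2. The step of a 14-fold higher number from compound 1 to compound 2 (1.15 log units; beyond the scatter) points the same way. The expected step for compound 4 is a 2.6-fold higher number from compound 3 to compound 4 (0.42 log units; beyond the scatter), and the estimate for compound 4 is 10000 nM, with a range from 4000 nM to 25000 nM.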

Compound 4, solubility: 100 nM
Estimate against measurement, compound 4: 100-fold (2.00 log units) above, and the stated range ends above it.
By their numbers in this assay, from the lowest: compound 4; then compound 1; then compound 3; then compound 2.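

In this assay, hydroxy in place of amino on an aromatic carbon gave a 190-fold lower number from compound 2 to compound 4 (2.27 log units; beyond the scatter), so the high number of compound 2 does not carry over to a hydroxy group on the same ring, and a single changed group decides a great deal here. The change from 2-fluorophenyl to 4-hydroxyphenyl gave a 38-fold lower number from compound 3 to compound 4 (1.58 log units; beyond the scatter), and the change from 3-methylpyridin-2-yl to 4-hydroxyphenyl gave a 13-fold lower number from compound 1 to compound 4 (1.11 log units; beyond the scatter), which leaves compound 4 lowest of the four and shows that the hydrogen-bond donor and acceptor counted for 4-hydroxyphenyl do not by themselves bring a higher number on this amide-type nitrogen. Nothing available gives a reason for this drop.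

Going by these compounds, it remains open whether a methoxy group or a carboxylic acid in place of the hydroxy would stay close to compound 4 or move towards compound 2. Also open, on these data alone, is whether 2-hydroxyphenyl, the direct counterpart of the 2-fluorophenyl in compound 3, would give a number as low as that of compound 4, which would tie the result to the hydroxy group rather than to where it sits.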